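Chloro to Nitro on the Pendant Phenyl Ring

The compounds below may be only part of what the source reports. "The series", "measured", "known", "first", "only" and "open" are said of these compounds alone.

Measured in an ADME assay on CCRF-CEM cells (Homo sapiens) for cytotoxicity, with a stated time of 72 h; on this read-out higher numbers stand for weaker inhibition and lower numbers for stronger inhibition:
- Compound 1, `Clc1ccc(Cc2nn3c(Br)c(-c4ccc(Cl)cc4)nc3s2)cc1`: compound 1 reaches only the limit > 250000 nM.
- Compound 2, `N#CSc1c(-c2ccc(Cl)cc2)nc2sc(Cc3ccc(Cl)cc3)nn12`: compound 2 gives 30000 nM.

Compound 2 holds the only definite number shown; the other value is a limit, (the limit of > 250000 nM in this assay, at which 1 of the 2 values shown sits). For the measured compounds named here, the one measured step, an at least 8.3-fold lower number from compound 1 to compound 2 (0.92 log units; beyond the scatter), concerns a change on the shared core rather than on the pendant phenyl ring.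

Compound 3, `N#CSc1c(-c2ccc([N+](=O)[O-])cc2)nc2sc(Cc3ccc(Cl)cc3)nn12`, differs from compound 2 in nitro in place of chloro on an aromatic carbon. Going by the values given here, no measured step touches this position, so there is nothing in the data to suggest the change should move the number beyond the scatter in either direction. The step is therefore expected to read no change at the digits printed from compound 2 to compound 3 (within the scatter). On this basis compound 3 is estimated at 30000 nM in this assay, within a range from 10000 nM to 100000 nM.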

Compound 3, half-maximal inhibitory concentration: 20000 nM
Compound 3: middle estimate off by 1.5-fold (0.18 log units), on the high side, within the range that was stated.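

In this assay, for the compounds shown here, going from 4-chlorophenyl to 4-nitrophenyl gives a 1.5-fold lower number from compound 2 to compound 3 (0.18 log units; within the scatter) and is the first measured change at this position. The number therefore stays within the scatter when chloro gives way to nitro, a group with more heavy atoms and with hydrogen-bond acceptors that chloro lacks. Nothing in the data shown offers a reason for this result.

The compounds shown place only chloro and nitro at this position, so they leave open whether an amine or a carboxylic acid there would move the number beyond the scatter. They also leave open whether nitro in place of chloro would read the same with bromo rather than cyanosulfanyl on the shared core.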